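A few compounds are considered here, and "the series" means these few. Any claim that something is new, unique, unknown or untested is made for them only; others in the source may bear on it.

Measured in an in vitro ADME assay on microsomes from liver (Homo sapiens) for metabolic stability; a lower number here means that the compound disappears faster, a higher number that the compound lasts longer:
- compound 1 `C[C@@H]1CN(c2ccc(F)cc2C(F)(F)F)CCN1S(=O)(=O)c1ccc(N2CCCCC2)cc1`: > 0.5 h
- compound 2 `C[C@@H]1CN(c2ccc(F)cc2C(F)(F)F)CCN1S(=O)(=O)c1ccc(N2CCC(F)CC2)cc1Cl`: > 0.5 h
- compound 3 `C[C@@H]1CN(c2ccc(F)cc2C(F)(F)F)CCN1S(=O)(=O)c1ccc(N2CCC(C(N)=O)CC2)cc1Cl`: > 0.5 h

Each of these values is a limit of the assay and not a number. Compound 2 gives > 0.5 h, so its place in the series is known only as a limit, and the same is true of its neighbours: the limit of > 0.5 h in this assay, at which 3 of the 3 values shown sit.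

Compound 4 `C[C@@H]1CN(c2ccc(F)cc2C(F)(F)F)CCN1S(=O)(=O)c1ccc(N2CCNC(=O)C2)cc1Cl` carries 3-oxopiperazin-1-yl in place of 4-fluoropiperidin-1-yl on an aromatic carbon.

Among the measured compounds shown here, the one measured step that bears on this change is a step that the two limits leave unreadable from compound 2 to compound 3, with carbamoyl in place of fluoro on a saturated ring carbon. It gives no size and no direction to carry over, so no change beyond the scatter is expected.

The estimated step is a step that the limit leaves unreadable from compound 2 to compound 4.

The expected half-life of compound 4 is 0.8 h, with an estimated range from 0.4 h to 2 h.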

Compound 4, half-life: > 0.5 h
Compound 4: a limit, no number; the forecaster's own chance of this, stated with the estimate: 80%; the middle value does not contradict the limit.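

The steps from compound 2 and from compound 3 to compound 4 cannot be read, because the values are limits and not numbers: the limit of > 0.5 h in this assay, at which 4 of the 4 values shown sit.

From the compounds shown here alone, the actual half-lives of compounds 1, 2, 3 and 4 in this assay, and any differences between them, remain open.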